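The source may report more compounds than this note shows. Statements on the series, on what has been measured and on what is new or still open speak of the compounds shown alone.

In a functional assay on HCT-116 cells (Homo sapiens), read by MTT assay, with a stated time of 72 h (a lower number here means a stronger inhibitor, a higher number a weaker inhibitor), compound 1 (`O=c1[nH]cnc2c1c(-c1ccccc1)cn2[C@@H]1O[C@H](CO)[C@@H](O)[C@H]1O`) reads > 20000 nM as a limit and not a number. Compound 2 (`O=c1[nH]cnc2c1c(-c1cc3ccccc3o1)cn2[C@@H]1O[C@H](CO)[C@@H](O)[C@H]1O`) reads > 20000 nM as a limit too. Compound 3 (`Cc1nc(N)c2c(-c3ccsc3)cn([C@@H]3O[C@H](CO)[C@@H](O)[C@H]3O)c2n1`) reads > 20000 nM as a limit as well. Compound 2 therefore stands with the other two at the limit of > 20000 nM in this assay, at which 3 of the 3 values shown sit, and has no number of its own.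

The next structure is compound 4 (`Nc1nc2c(c(-c3cc4ccccc4o3)cn2[C@@H]2O[C@H](CO)[C@@H](O)[C@H]2O)c(=O)[nH]1`), and the change is amino in place of hydrogen on an aromatic carbon with the amino group on the aromatic carbon between two ring nitrogen atoms. Among the measured compounds shown here, the only measured step is a step that the two limits leave unreadable from compound 1 to compound 2 and it has no readable size and concerns a different group. For the measured compounds named here, no measured step shows what this amino group does at that place.

Going by the values given here, with all three readings at the limit, no step of readable size is expected in this assay in either direction. The estimated a number no higher from compound 2 to compound 4 (the limit leaves the size open) is a working figure only. For compound 4 the estimated value is 20000 nM with an expected range from 7000 nM to 40000 nM and a report as a limit is the likeliest outcome.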

Compound 4, half-maximal inhibitory concentration: > 100000 nM
Compound 4 was reported as a limit (the forecaster's own chance of this, stated with the estimate: 80%); at least 5.0-fold (0.69 log units) between middle value and limit.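

Among the compounds shown here, compound 2 and compound 4 are both reported as limits in this assay, and no step of readable size can be taken from the pair. The compounds shown leave open whether amino in place of hydrogen changes the read-out at all: none of the four has a number of its own.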